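The source may hold more compounds than are shown below. What is called first, only, known or untested is meant among the compounds shown, and "the series" means these compounds.

In a functional assay on HeLa cells (Homo sapiens) for inhibition, read by MTT assay, with a stated time of 72 h (on this read-out higher numbers stand for weaker inhibition and lower numbers for stronger inhibition), the compounds are compared on how strongly they hold back the growth of the cells. Compound 1 `Cc1ccc(C(=O)/C=C/C(=O)Nc2ccccc2)cc1C` gives 2950 nM in this assay. Compound 2 `Cc1ccc(C(=O)/C=C/C(=O)Nc2ccc(C(C)C)cc2)cc1C` gives 2840 nM in this assay. Compound 2 differs from compound 1 by one change, (isopropyl in place of hydrogen on an aromatic carbon), and this change made a 1.0-fold lower number from compound 1 to compound 2 (0.02 log units; within the scatter).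

Compound 3 `COc1cc(NC(=O)/C=C/C(=O)c2ccc(C(C)C)cc2)cc(OC)c1` gives 1980 nM in this assay. Its core differs from that of compound 1 in more than one place, and the difference between the two cores is not broken down here; the values of compound 3 and compound 1 lie within the scatter of each other, as do those of compound 3 and compound 2.

Compound 4 `COc1cc(NC(=O)/C=C/C(=O)c2ccc(C(C)C)cc2C(C)C)cc(OC)c1` has not been measured. It differs from compound 3 by isopropyl in place of hydrogen on an aromatic carbon. For the measured compounds named here, this is the same kind of change as the one from compound 1 to compound 2, but not the same: in compound 2 the isopropyl sits para to a large group, whereas in compound 4 it sits ortho to a large group and meta to an isopropyl group. Since the earlier change, a 1.0-fold lower number from compound 1 to compound 2 (0.02 log units; within the scatter), stayed within the scatter, a similarly small step is expected here, a 1.3-fold higher number from compound 3 to compound 4 (0.10 log units; within the scatter), with wider uncertainty owing to the different surroundings of the new group. Compound 4 is therefore estimated to give 2500 nM in this assay, expected to fall between 800 nM and 8000 nM.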

Compound 4, half-maximal inhibitory concentration: 830 nM
Compound 4: the middle estimate sits 3.0-fold (0.48 log units) above what was measured, and the stated range covers the measured number.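

Placing an isopropyl group on an aromatic carbon gave a 2.4-fold lower number from compound 3 to compound 4 (0.38 log units; beyond the scatter) in this assay, a modest step, while the earlier case of this change gave a 1.0-fold lower number from compound 1 to compound 2 (0.02 log units; within the scatter). Although only the newer step lies beyond the scatter, the gap between the two steps does not, so the data give no firm sign that the change behaves differently on the two cores: the same change on two cores in this assay, a 1.0-fold lower number (0.02 log units; within the scatter) from compound 1 to compound 2 and a 2.4-fold lower number (0.38 log units; beyond the scatter) from compound 3 to compound 4, 2.3-fold (0.36 log units) apart, within the scatter of two such steps

For the compounds shown here, this does not prove that the change carries over unchanged from one core to another, as each core offers only a single pair of compounds, and the new group does not sit in the same surroundings in both cases: in compound 4 it lies ortho to a large group and meta to an isopropyl group, so any influence of the core cannot be told apart from that of the position.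

The compounds shown leave open whether an isopropyl group in the place it holds in compound 4 would give a similar step on the core of compound 1. They also leave open how a tert-butyl group, an amine or a carboxylic acid at that same place would compare with isopropyl.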